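Chloro-to-amino exchange on the shared core, both benzyl isomers

The source may report more compounds than this note shows. Statements on the series, on what has been measured and on what is new or still open speak of the compounds shown alone.

Of the compounds shown here, three have been measured in a functional assay on MCF7 cells (Homo sapiens) for cytotoxicity, read by sulforhodamine B assay, with a stated time of 48 h; a higher number here means a weaker inhibitor of growth, a lower number a stronger inhibitor of growth. Compound 3 `ClCc1ccc(Cn2cnc3c(Cl)nc(Cl)nc32)cc1` gives 3980 nM. Compound 2 `ClCc1cccc(Cn2cnc3c(Cl)nc(Cl)nc32)c1` gives 6450 nM; compound 2 and compound 3 have the same atoms joined differently, and the difference between the two cores is not broken down here. The two values lie within the usual scatter of each other. Compound 1 `Nc1nc(Cl)c2ncn(Cc3ccc(CCl)cc3)c2n1` gives 17000 nM.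

One structural change has a measured step: from compound 3 to compound 1, (amino in place of chloro on an aromatic carbon). This gave a 4.3-fold higher number from compound 3 to compound 1 (0.63 log units; beyond the scatter).

Compound 4 `Nc1nc(Cl)c2ncn(Cc3cccc(CCl)c3)c2n1` is not yet measured. It differs from compound 2 by amino in place of chloro on an aromatic carbon, which is the same change, at a place described in the same words, as that from compound 3 to compound 1.

For the measured compounds named here, with only one measured example of this change, the expectation for compound 4 rests on that single step. Because a 4.3-fold higher number from compound 3 to compound 1 (0.63 log units; beyond the scatter) shows a higher number after the exchange, the step from compound 2 to compound 4 is expected to be of similar size, estimated as a 4.2-fold higher number from compound 2 to compound 4 (0.62 log units; beyond the scatter). Compound 4 is therefore estimated at 27000 nM in this assay, with a range from 12000 nM to 60000 nM allowing for the scatter and for the core difference between compound 2 and compound 3 not being broken down.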

Compound 4, concentration for total growth inhibition: 9550 nM
For compound 4 the middle estimate is 2.8-fold (0.45 log units) above the measured one; the measured number lies below the stated range.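

In this assay, amino in place of chloro on an aromatic carbon gives a 1.5-fold higher number from compound 2 to compound 4 (0.17 log units; within the scatter), so on this core the values before and after the exchange cannot be told apart. The step measured on one core therefore did not carry over in size to the other, and the two steps differ by more than the scatter allows: the same change on two cores in this assay, a 4.3-fold higher number (0.63 log units; beyond the scatter) from compound 3 to compound 1 and a 1.5-fold higher number (0.17 log units; within the scatter) from compound 2 to compound 4, 2.9-fold (0.46 log units) apart, beyond the scatter of two such steps

For the compounds shown here, this is one pair on each core, so it shows only that a step measured on one benzyl isomer is a poor guide to the same exchange on the other in this assay; it gives no reason for the gap and no rule for any further core, and a shared direction cannot be claimed for a step that stays within the scatter.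

The compounds shown leave open whether the gap goes with the place of the chloromethyl group on the benzyl ring or with something else that differs between the two cores. They also leave open how other groups on the same aromatic carbon, such as methylamino or methoxy, or a hydroxymethyl group in place of chloromethyl, would read in this assay on either core.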